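Methyl on the ring amine: compound 2 to compound 3

The source may report more compounds than this note shows. Statements on the series, on what has been measured and on what is new or still open speak of the compounds shown alone.

Measured so far:
compound 1, `COc1cc(C2=CC3CC(C2)CN(C)C3)cnc1Cl`, 4.4 nM
compound 2, `Clc1ccncc1C1=CC2CNCC(C1)C2`, 3 nM

In an in vitro assay on SH-EP1 cells for displacement of a labelled ligand from Neuronal acetylcholine receptor; alpha4/beta2 (Homo sapiens) (a lower number here means a stronger inhibitor, a higher number a weaker inhibitor), compound 2 gives the lowest of the two numbers, and compound 1 stands within the scatter of it. Compound 3, `CN1CC2C=C(c3cnccc3Cl)CC(C2)C1`, differs from compound 2 by methyl in place of hydrogen on an amine nitrogen in a ring. Among the compounds with values here, no step of this kind has been measured here, and compound 1, which already carries a methyl on that nitrogen, is within the scatter of compound 2. Compound 3 is therefore expected to change little, a step of a 2.0-fold higher number from compound 2 to compound 3 (0.30 log units; within the scatter) toward a slightly higher number at most. The estimate for compound 3 is 6 nM, with a range from 2 nM to 20 nM.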

Compound 3, inhibition constant: 1160 nM
Beside the measured number, compound 3's estimate is 190-fold (2.29 log units) below it; measured number above the stated range.
By their numbers in this assay, from the lowest: compounds 2 and 1 (each within the scatter of the next); then compound 3.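

In this assay, methyl in place of hydrogen on an amine nitrogen in a ring gives a 390-fold higher number from compound 2 to compound 3 (2.59 log units; beyond the scatter) and shows that this one added carbon is far from a silent change on the core of compound 2. Compound 1 also carries that methyl, but it differs from compound 3 in more than one place, so its value cannot be set against this step. Nothing in the data shown explains the size of the step. From the compounds shown here alone, it remains open whether an ethyl group or a longer chain on that nitrogen would give a similar step. Also open, going by these compounds, is what hydrogen in place of the methyl would do on the core of compound 1.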